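The source may report more compounds than this note shows. Statements on the series, on what has been measured and on what is new or still open speak of the compounds shown alone.

Measured in an ADME assay on microsomes from liver (Mus musculus) for metabolic stability, read by LC-MS, with a stated time of 30 min, tested at 1 uM; a lower number here means that less of the compound is left, a higher number that more of the compound is left:
- compound 1 `Cc1ccccc1S(=O)(=O)c1ccc(CNC(=O)c2cc3cnccc3[nH]2)cc1`: 15%
- compound 2 `O=C(NCc1ccc(S(=O)(=O)c2ccccc2)cc1)c1cc2ccncc2s1`: 21%
- compound 3 `Cn1c(C(=O)NCc2ccc(S(=O)(=O)c3ccccc3)cc2)cc2cnccc21`: 34%

In this assay, compound 1 at 15% lies within the scatter of compound 2 at 21%, while compound 3 at 34% stands higher than compound 1, beyond the scatter.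

Compound 4 `O=C(NCc1ccc(S(=O)(=O)c2ccc(F)c(F)c2)cc1)c1cc2cnccc2[nH]1` keeps the core of compound 1 and has 3,4-difluorophenyl in place of 2-methylphenyl on a sulfonyl sulfur. Going by the values given here, no measured pair shows this change. Neither compound 2 nor compound 3 carries the 2-methylphenyl, but both also differ from compound 1 in the core, so they guide the expectation only loosely. A modest upward step is expected, near the edge of the scatter, and the estimated step is a number 10 percentage points higher from compound 1 to compound 4 (within the scatter). For compound 4 the expected value is 25%, with an estimated range from 12% to 42%.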

Compound 4, percent of the compound remaining: 58%
Compound 4: the middle estimate sits 33 percentage points below what was measured; the measured number lies above the stated range.
By their numbers in this assay, from the lowest: compounds 1 and 2 (each within the scatter of the next); then compound 3; then compound 4.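

With the core of compound 1 held fixed, 3,4-difluorophenyl in place of 2-methylphenyl on a sulfonyl sulfur gives, in this assay, a number 43 percentage points higher from compound 1 to compound 4 (beyond the scatter) and is the first step shown at this position. It shows that the aryl group on the sulfonyl sulfur alone can move the percent of compound remaining by a large amount, with no change in the core. Nothing measured here accounts for this rise. Still open, from the compounds shown here alone, is whether losing the methyl or gaining the fluorines drives the step. Also open, going by these compounds, is how a methoxyphenyl or a pyridyl group would fare on this sulfonyl sulfur.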